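The source may hold more compounds than are shown below. What is called first, only, known or untested is meant among the compounds shown, and "the series" means these compounds.

In a functional assay on A-375 cells (Homo sapiens) for antiproliferative activity, read by MTT assay, with a stated time of 72 h (on this read-out higher numbers stand for weaker inhibition and lower numbers for stronger inhibition), compound 1 (`COc1ccc(N2C(=O)COc3ccc(-c4cnc(Cl)c(NS(=O)(=O)c5ccc(F)cc5)c4)cc32)cc1`) gives 32700 nM and compound 2 (`CC(C)N1C(=O)COc2ccc(-c3cnc(Cl)c(NS(=O)(=O)c4ccc(F)cc4)c3)cc21`) gives 25500 nM so the two stand within the scatter of each other. Compound 3 (`COc1ccc(N2C(=O)COc3ccc(-c4cnc(OC)c(NS(=O)(=O)c5ccc(F)cc5)c4)cc32)cc1`) keeps the core of compound 1 but carries methoxy in place of chloro on an aromatic carbon. Going by the values given here, the only measured step (a 1.3-fold lower number from compound 1 to compound 2 (0.11 log units; within the scatter)) lies at the amide-type nitrogen in a ring, so no measurement covers this change. A moderate move toward stronger inhibition is expected on the structural change alone, an estimated step (a 2.7-fold lower number from compound 1 to compound 3 (0.44 log units; beyond the scatter)) with weak support. The estimate for compound 3 is 12000 nM within an expected range from 2000 nM to 40000 nM in this uncertain case.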

Compound 3, half-maximal inhibitory concentration: 18400 nM
Compound 3: the middle estimate sits 1.5-fold (0.19 log units) below what was measured, within the range that was stated.
By their numbers in this assay, from the lowest: compounds 3, 2 and 1 (each within the scatter of the next).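

In this assay, going by these compounds alone, the position next to the ring nitrogen, which the earlier compounds left unchanged, now has a reading: methoxy in place of chloro gives a 1.8-fold lower number from compound 1 to compound 3 (0.25 log units; within the scatter) and so does not separate the two groups. The swap adds one heavy atom and one hydrogen-bond acceptor at this place, with no step beyond the scatter. No measured evidence explains this result. The compounds shown leave open whether an amine, a carboxylic acid or a longer alkoxy chain here would move the number beyond the scatter. They also leave open whether methoxy gives a similar reading with isopropyl on the amide-type nitrogen in a ring.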